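Naphthalen-1-yl in Place of Phenyl on a Sulfur

The source may hold more compounds than are shown below. What is called first, only, known or untested is meant among the compounds shown, and "the series" means these compounds.

Compound 1 `CS(=O)(=O)c1ccc(-c2nc3ccccn3c2Sc2ccccc2)cc1` gives 77200 nM in a functional assay on U-87MG ATCC cells for inhibition, with U-87 MG (Homo sapiens) as the target, read by MTT assay, with a stated time of 48 h (on this read-out lower numbers stand for stronger inhibition and higher numbers for weaker inhibition), the only number measured among the two compounds shown. Compound 2 `COc1ccc(-c2nc3ccccn3c2Sc2ccccc2)cc1` reaches only a limit in this assay, > 100000 nM. The step of an at least 1.2-fold higher number from compound 1 to compound 2 (0.11 log units; that floor lies within the scatter) is methoxy in place of methylsulfonyl on an aromatic carbon, and the limit of > 100000 nM in this assay, at which 1 of the 2 values shown sits, caps what that step can show. Compound 3 `CS(=O)(=O)c1ccc(-c2nc3ccccn3c2Sc2cccc3ccccc23)cc1` differs from compound 1 by naphthalen-1-yl in place of phenyl on a sulfur. Among the compounds with values here, no measured step touches the group on the sulfur, so compound 1 is the only anchor. Compound 3 is expected near 60000 nM, within 20000 nM to 100000 nM, a step of a 1.3-fold lower number from compound 1 to compound 3 (0.11 log units; within the scatter) that stays inside the scatter.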

Compound 3, half-maximal inhibitory concentration: 56200 nM
Compound 3: middle estimate off by 1.1-fold (0.03 log units), on the high side, within the range that was stated.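

Unlike the earlier step, which ends at a limit, this one joins two measured numbers in this assay: a 1.4-fold lower number from compound 1 to compound 3 (0.14 log units; within the scatter). Replacing the single aromatic ring on the sulfur with naphthalen-1-yl, which has two such rings, therefore produces no change that can be told from the scatter. No measurement shown here offers an explanation for this result.

As far as these compounds go, it remains open whether a group of another kind on the sulfur, such as an amine, a carboxylic acid or a longer chain, would give a step beyond the scatter.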